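The compounds below may be only part of what the source reports. "The series", "measured", "known", "first", "only" and "open" are said of these compounds alone.

Measured so far:
- compound 1, `N#Cc1cnc(NCc2cnccc2C(F)(F)F)cc1N[C@H]1C[C@@H](O)C1`: > 10000 nM (a limit, not a number)
- compound 2, `N#Cc1cnc(NCc2ccccc2C(F)(F)F)cc1N[C@H]1C[C@@H](C(N)=O)C1`: 4200 nM
- compound 3, `N#Cc1cnc(NCc2ccccc2C(F)(F)F)cc1N[C@H]1C[C@H](C(N)=O)C1`: > 10000 nM (a limit, not a number)

In an assay on isolated protein for inhibition of protein kinase C delta type (Homo sapiens), read by TR-FRET, with a stated time of 2 h (a lower number here means a stronger inhibitor, a higher number a weaker inhibitor), compound 1 gives only a limit, > 10000 nM, so no number is known for it. Compound 3 likewise sits at the limit of this assay. Among the measured compounds shown here, the one numbered value is that of compound 2, and the sole measured step is an at least 2.3-fold higher number from compound 2 to compound 3 (0.37 log units; beyond the scatter); it shows that the configuration of the carbamoyl-bearing cyclobutyl alone moves the read-out beyond the scatter, due to the fact that compounds 2 and 3 differ only in the configuration as drawn, while the limit of > 10000 nM in this assay, at which 2 of the 3 values shown sit, leaves the size of that move open.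

Compound 4 is `CC1(C)[C@@H](Nc2cc(NCc3cnccc3C(F)(F)F)ncc2C#N)C[C@H]1C(N)=O`. Relative to compound 1 the change is 3-carbamoyl-2,2-dimethylcyclobutyl in place of 3-hydroxycyclobutyl on a nitrogen on an aromatic ring. For the measured compounds named here, no measured step covers this exact change; the nearest evidence is that compound 2, which also carries a carbamoyl on the cyclobutyl, reaches 4200 nM. The hydroxy analogue compound 1, on the other hand, gives only a limit in this assay. Going by the values given here, a move toward a measurable number is therefore expected for compound 4, the more so if its configuration matches compound 2 rather than compound 3, but the added dimethyl has no precedent here.

Compound 4 is expected near 6000 nM, within 1500 nM to 20000 nM, an estimated step of an at least 1.6-fold lower number from compound 1 to compound 4 (0.22 log units; that floor lies within the scatter).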

Compound 4, half-maximal inhibitory concentration: 4500 nM
Beside the measured number, compound 4's estimate is 1.3-fold (0.12 log units) above it; measured number inside the range.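

In this assay, 3-carbamoyl-2,2-dimethylcyclobutyl in place of 3-hydroxycyclobutyl on a nitrogen on an aromatic ring gives an at least 2.2-fold lower number from compound 1 to compound 4 (0.34 log units; beyond the scatter). Among the compounds shown here, this is the first measured number on the core of compound 1, so this position accepts the larger group, with its two added methyls, without the read-out staying at the limit of the assay. The step is only a floor and its full size stays unknown, because compound 1 is known only as a limit and not as a number: the limit of > 10000 nM in this assay, at which 2 of the 4 values shown sit.

The change brings in the carbamoyl and the two methyls together, so the compounds shown do not separate their shares in the step, and the mirror-image partner of compound 4 has no value here to show whether configuration counts on this core as well. Also open, as far as these compounds go, is how a carboxylic acid or an aminomethyl group in place of the carbamoyl on the 2,2-dimethylcyclobutyl would read in this assay.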